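The source may report more compounds than this note shows. Statements on the series, on what has been measured and on what is new or still open speak of the compounds shown alone.

Measured in an ADME assay on MT4 cells (Homo sapiens) for cytotoxicity, read by MTT assay, with a stated time of 5 days; a higher number here means that more compound is tolerated, a lower number that less compound is tolerated; each of the three values is a limit:

- Compound 1 `COc1cc2nc([S+]([O-])CC(=O)Nc3cccc([N+](=O)[O-])c3)nc(Nc3c(Cl)cc(/C=C/C#N)cc3Cl)c2cc1OC`: >= 83200 nM
- Compound 2 `COc1cc2nc([S+]([O-])CC(=O)Nc3ccc(S(N)(=O)=O)cc3)nc(Nc3c(Cl)cc(/C=C/C#N)cc3Cl)c2cc1OC`: > 189000 nM
- Compound 3 `COc1cc2nc([S+]([O-])CC(=O)Nc3cc([N+](=O)[O-])ccc3F)nc(Nc3c(Cl)cc(/C=C/C#N)cc3Cl)c2cc1OC`: > 194000 nM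

Compound 3 has no exact figure in this assay. Compound 3 stands at > 194000 nM, which is a limit, and the values of compound 1 and compound 2 are limits too.

The next compound is compound 4 `COc1cc2nc([S+]([O-])CC(=O)Nc3c(C)cc(C)cc3C)nc(Nc3c(Cl)cc(/C=C/C#N)cc3Cl)c2cc1OC`, with 2,4,6-trimethylphenyl in place of 2-fluoro-5-nitrophenyl on an amide-type nitrogen.

Two measured steps end at compound 3 and bear on this change: a step that the two limits leave unreadable from compound 1 to compound 3 and a step that the two limits leave unreadable from compound 2 to compound 3. Neither gives a size or a direction. All that carries over is that all three measured compounds end in a limit, and none goes against this.

Compound 4 is expected to stay near the limit of compound 3, with any shift toward less compound tolerated. The expected step is an at least 1.6-fold lower number from compound 3 to compound 4 (0.20 log units; that floor lies within the scatter). For compound 4 the estimate is 120000 nM, with an expected range from 30000 nM to 200000 nM.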

Compound 4, half-maximal cytotoxic concentration: 8870 nM
Compound 4: middle estimate off by 14-fold (1.13 log units), on the high side, and the stated range ends above it.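

In this assay, this amide-type nitrogen gives its first readable result: compound 4 has an exact value, while the steps among compound 1, compound 2 and compound 3 cannot be read, since all three values are limits. Placing 2,4,6-trimethylphenyl on the nitrogen gives an at least 21-fold lower number from compound 3 to compound 4 (1.33 log units; beyond the scatter) and an at least 21-fold lower number from compound 2 to compound 4 (1.32 log units; beyond the scatter), both large, as well as an at least 9.3-fold lower number from compound 1 to compound 4 (0.97 log units; beyond the scatter), so the group on this nitrogen can clearly change how much compound is tolerated. Each of these sizes is only a floor, set by a limit on the starting compound.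

The compounds shown leave open whether the drop needs all three methyl groups, which a plain phenyl or a methylphenyl on the same nitrogen would test. They also leave open whether an aminophenyl or a carboxyphenyl there would keep the number at a limit, and no measurement here explains the step.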